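The compounds below may be only part of what the source reports. "The series", "measured", "known", "first", "only" and "open" are said of these compounds alone.

Compound 1 `Cc1cnc(NC(=O)c2cc(Oc3ccc(S(C)(=O)=O)cc3)c3cn(C)nc3c2)cn1`: < 8 mL/min/kg
Compound 2 `CCS(=O)(=O)c1ccc(Oc2cc(C(=O)Nc3cnc(C)cn3)cc3nn(C)cc23)cc1`: < 8 mL/min/kg

In an in vitro ADME assay on microsomes from liver (Homo sapiens) for metabolic stability (a lower number here means slower removal, a higher number faster removal of the compound), compound 1 gives < 8 mL/min/kg, which is a limit of the assay and not a number. Compound 2 gives < 8 mL/min/kg, which is also a limit. Going by these compounds, both compounds therefore sit at the limit of < 8 mL/min/kg in this assay, at which 2 of the 2 values shown sit, and the true position of compound 1 beneath it is unknown.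

The next compound, compound 3 `CCCn1cc2c(Oc3ccc(S(C)(=O)=O)cc3)cc(C(=O)Nc3cnc(C)cn3)cc2n1`, keeps the shared core and changes one group: ethyl in place of hydrogen on a saturated chain carbon bound to an aromatic nitrogen. In words, this is ethyl in place of hydrogen on a saturated chain carbon bound to an aromatic nitrogen, so methyl becomes propyl.

For the measured compounds named here, only one measured step offers any guidance, a step that the two limits leave unreadable from compound 1 to compound 2. It is a different change, methyl in place of hydrogen on a saturated chain carbon bound to a sulfonyl sulfur, and it gives no size to carry over. The forecast is therefore loose. The expected step is an at least 1.1-fold higher number from compound 1 to compound 3 (0.05 log units; that floor lies within the scatter), a modest rise in clearance at most, and another limit would be no surprise. For compound 3 the estimated clearance is 9 mL/min/kg, with an expected range of 5 mL/min/kg to 20 mL/min/kg.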

Compound 3, clearance: < 8 mL/min/kg
Compound 3 was reported as a limit; the forecaster's own chance of this, stated with the estimate: 45%; at least 1.1-fold (0.05 log units) between middle value and limit.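

In this assay compound 3 gives < 8 mL/min/kg, which is a limit of the assay and not a number. Compound 1 also has only a limit, so the step between these two compounds cannot be read. All three compounds stand together: the limit of < 8 mL/min/kg in this assay, at which 3 of the 3 values shown sit. Going by these compounds, whether propyl in place of methyl changes clearance at all, and by how much, stays open.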